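The compounds below may be only part of what the source reports. "The series", "measured", "known", "first", "only" and "open" are said of these compounds alone.

For the measured compounds named here, compound 2 `CCn1cc(-c2nc3ccc(Cl)cc3[nH]2)c(=O)c2cc(F)c(N3CCNCC3)cc21` stands highest of the two numbers so far in a functional assay on A549 cells (Homo sapiens) for cytotoxicity, read by sulforhodamine B assay, with a stated time of 48 h (on this read-out lower numbers stand for stronger inhibition of growth and higher numbers for weaker inhibition of growth), where compound 2 gives 1000 nM. Its nearest neighbour is compound 1 `CCn1cc(-c2nc3ccccc3[nH]2)c(=O)c2cc(F)c(N3CCNCC3)cc21`; in this assay compound 1 gives 600 nM, and the step of a 1.7-fold higher number from compound 1 to compound 2 (0.22 log units; within the scatter) lies within the scatter. Compound 3 `CCn1cc(-c2nc3ccc(N)cc3[nH]2)c(=O)c2cc(F)c(N3CCNCC3)cc21` differs from compound 2 on the same aromatic carbon: amino in place of chloro on an aromatic carbon. Going by the values given here, the only measured step bearing on this carbon, a 1.7-fold higher number from compound 1 to compound 2 (0.22 log units; within the scatter), put chloro in place of hydrogen and moved the number less than the scatter, so the exchange of chloro for amino has no direct precedent of its own. With one small step to go on, no step beyond the scatter is expected in this assay from compound 2 to compound 3, in either direction. Compound 3 is therefore estimated at 700 nM, with a range of 250 nM to 2000 nM, which is expected to mean a step of a 1.4-fold lower number from compound 2 to compound 3 (0.15 log units; within the scatter).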

Compound 3, concentration for 50% growth inhibition: > 10000 nM
Compound 3 was reported as a limit; the forecaster's own chance of this, stated with the estimate: 5%; middle value at least 14-fold (1.15 log units) from the limit.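

In this assay compound 3 gives > 10000 nM, which is a limit of the assay and not a number. This aromatic carbon does not treat all small groups alike: amino in place of hydrogen gives an at least 16-fold higher number from compound 1 to compound 3 (1.22 log units; beyond the scatter), and amino in place of chloro gives an at least 10-fold higher number from compound 2 to compound 3 (1.00 log units; beyond the scatter), both beyond the scatter, whereas chloro in place of hydrogen stayed within it. The full size of both amino steps remains unknown, as each rests on a limit: the limit of > 10000 nM in this assay, at which 1 of the 3 values shown sits.

The compounds shown leave open whether this loss of growth inhibition belongs to the amino group alone or extends to other groups on this carbon, such as a dimethylamino group, an acetamide or a methoxy group. They also leave open whether an amino group on another carbon of the same ring would give a comparable step.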